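A few compounds are considered here, and "the series" means these few. Any claim that something is new, unique, unknown or untested is made for them only; others in the source may bear on it.

In a functional assay on the whole organism with Scenedesmus acutus as the target (a higher number here means a weaker inhibitor, a lower number a stronger inhibitor), compound 1 (`COC(=O)c1cc(N2C(=O)C3=C(CCCC3)C2=O)ccc1Cl`) gives 2000 nM, while compound 2 (`CC(C)COC(=O)c1cc(N2C(=O)C3=C(CCCC3)C2=O)c(F)cc1Cl`) gives 33.1 nM, the lower of the two numbers and clear of the usual scatter. That makes compound 2 the stronger inhibitor of this pair. Compound 3 (`CC(C)COC(=O)c1cc(N2C(=O)C3=C(CCCC3)C2=O)ccc1Cl`) comes from compound 2 by a single swap: hydrogen in place of fluoro on an aromatic carbon. Going by the values given here, no two measured compounds differ in one place only, so the size of this swap has not been seen directly. In this assay, a moderate rise in the number is expected, one that clears the scatter but stays well short of the whole gap to compound 1, which gives 2000 nM. The expected step is a 3.9-fold higher number from compound 2 to compound 3 (0.59 log units; beyond the scatter). The estimated value for compound 3 is 130 nM, with a likely range from 40 nM to 500 nM.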

Compound 3, half-maximal inhibitory concentration: 759 nM
Beside the measured number, compound 3's estimate is 5.8-fold (0.77 log units) below it; the whole stated range lies below it.
By their numbers in this assay, from the lowest: compound 2; then compound 3; then compound 1.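

In this assay, the fluoro, ortho to a large group, turns out to matter far more than its single atom might suggest: hydrogen in its place gives a 23-fold higher number from compound 2 to compound 3 (1.36 log units; beyond the scatter), a large step from one small swap. The change in the ester is modest by comparison, since isopropyl in place of hydrogen on the saturated chain carbon bound to an oxygen next to a carbonyl group gives a 2.6-fold lower number from compound 1 to compound 3 (0.42 log units; beyond the scatter). Nothing available here explains why the fluoro counts for so much.

Still open, as far as these compounds go, is whether fluoro is uniquely suited to this place on the ring, or whether a bromo, methyl or methoxy group would serve as well. Also open, from the compounds shown here alone, is how a longer chain or a carboxylic acid would compare with the isobutoxycarbonyl group.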